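Methoxy for methyl on the aromatic ring

This account rests on a few compounds, and the source may have more. Where it says the series, first, only, none or still open, it means among the compounds named here.

In a functional assay on P388 cells (Mus musculus) for inhibition (a lower number here means a stronger inhibitor, a higher number a weaker inhibitor), compound 1 (`O=C1CCCCC/C1=C\c1cccc(Cl)c1`) gives 25700 nM and compound 2 (`Cc1cccc(/C=C2\CCCCCC2=O)c1`) gives 29800 nM. Compound 2 therefore stands level with compound 1, the two values lying within the scatter of each other. The next compound, compound 3 (`COc1cccc(/C=C2\CCCCCC2=O)c1`), has methoxy in place of methyl on an aromatic carbon, meta to a group of 9 heavy atoms: methoxy in place of methyl on an aromatic carbon. Within the data shown here, only one measured step bears on this change: a 1.2-fold higher number from compound 1 to compound 2 (0.06 log units; within the scatter), which is methyl in place of chloro on an aromatic carbon. Among the measured compounds shown here, that step is small, but no measured compound carries methoxy, so the support is thin. No step beyond the scatter is expected in this assay, and no direction is favoured. The expected step is a 1.1-fold lower number from compound 2 to compound 3 (0.03 log units; within the scatter). Compound 3 is estimated at 28000 nM, with an expected range of 14000 nM to 56000 nM.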

Compound 3, half-maximal inhibitory concentration: 50000 nM
For compound 3 the middle estimate is 1.8-fold (0.25 log units) below the measured one; the measured number falls inside the stated range.
By their numbers in this assay, from the lowest: compounds 1, 2 and 3 (each within the scatter of the next).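

In this assay, methoxy in place of methyl on an aromatic carbon, meta to a group of 9 heavy atoms, gives a 1.7-fold higher number from compound 2 to compound 3 (0.22 log units; within the scatter) and methoxy in place of chloro gives a 1.9-fold higher number from compound 1 to compound 3 (0.29 log units; within the scatter) as its reading. Compound 3 brings the only hydrogen-bond acceptor on this aromatic ring among the compounds shown, yet chloro, methyl and methoxy at this place remain within the scatter of one another, so the series does not separate them. Nothing measured here offers an explanation for these values.

Open, on these data alone, is whether an amine, a carboxylic acid or a longer chain such as ethoxy at this place would give a step beyond the scatter. Also open, as far as these compounds go, is how any of these groups would read at another carbon of the aromatic ring.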